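The source may hold more compounds than are shown below. What is called first, only, known or untested is meant among the compounds shown, and "the series" means these compounds.

Measured compounds:
- compound 1, `COc1c(C)cnc(CN2CC(=O)N(CC(C)C)c3c(Cl)nc(N)nc32)c1C`: 10 nM
- compound 2, `COc1c(C)cnc(CN2c3nc(N)nc(Cl)c3NC(=O)[C@H]2C)c1C`: 220 nM

In a functional assay on SK-BR-3 cells (Homo sapiens) for inhibition (a higher number here means a weaker inhibitor, a lower number a stronger inhibitor), compound 1 gives 10 nM, and compound 2 gives 220 nM. Compound 2 therefore has the higher of the two numbers, and its gap to compound 1 is beyond the scatter of repeated measurements. Compound 1 and compound 2 differ in more than one place, so nothing can be said about which part of the change carries the difference.

Compound 3, `COc1c(C)cnc(CN2c3nc(N)nc(Cl)c3NC(=O)[C@@H]2C)c1C`, has not yet been measured in this assay. It differs from compound 2 as follows: the two compounds have the same atoms and bonds and differ only in configuration as drawn: 1 of 1 stereo elements differ; a stereocentre at a saturated ring carbon is drawn R in compound 2 and S in compound 3. A change of configuration alone gives no guide from the two measured values, since both have their own drawn configuration and neither pair shares a single point of difference. It is reasonable to expect that the two configurations will not give the same number, but which of them sits lower is open. The step expected from compound 2 to compound 3 is a 2.2-fold lower number from compound 2 to compound 3 (0.34 log units; beyond the scatter), with wide uncertainty in both directions. For compound 3 the estimate is 100 nM, with a range from 10 nM to 1000 nM.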

Compound 3, half-maximal inhibitory concentration: 250 nM
Beside the measured number, compound 3's estimate is 2.5-fold (0.40 log units) below it, and the stated range covers the measured number.
By their numbers in this assay, from the lowest: compound 1; then compounds 2 and 3 (each within the scatter of the next).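

In this assay, inverting the saturated ring carbon gives a 1.1-fold higher number from compound 2 to compound 3 (0.06 log units; within the scatter), so at this position the R and S drawings cannot be told apart by their numbers. The earlier compounds shown here could not show this, since compound 1 and compound 2 differ in more than one place, whereas this pair isolates a single change, and the reading rests on one point: the fact that compounds 2 and 3 differ only in the configuration as drawn. Going by these compounds alone, neither configuration reaches the number of compound 1, at 10 nM, but compound 1 differs from both in more than one place, so its gap to them remains unassigned, and this pair shows only that the choice of configuration at this carbon carries no measurable step here.

The compounds shown leave open whether the same indifference to configuration would hold with a longer chain, such as an ethyl or a propyl group, or with a hydroxymethyl group at this stereocentre. They also leave open what would happen to either configuration if the amide hydrogen were replaced by a chain such as an ethyl group.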